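The source may hold more compounds than are shown below. What is called first, only, known or untested is meant among the compounds shown, and "the series" means these compounds.

Compound 1 `CN(C)C(=O)c1cc2cnc(Nc3ccc(NC(=O)C4(C(=O)Nc5ccccc5F)CC4)cc3)nc2n1C1CCCC1`: 79.1%
Compound 2 `CN(C)C(=O)c1cc2cnc(Nc3ccc(NC(=O)C4(C(=O)Nc5cccc(F)c5)CC4)cc3)nc2n1C1CCCC1`: 33.2%

Going by the values given here, in a functional assay on A549 cells (Homo sapiens) for inhibition, read by CCK-8 assay, with a stated time of 72 h, tested at 1 uM (a lower number here means less inhibition of growth, a higher number more inhibition of growth at the concentration tested), compound 2 stands lowest of the two measured numbers, with compound 1 as its only neighbour, well beyond the scatter above it. Compound 3 `COc1ccc(NC(=O)C2(C(=O)Nc3ccc(Nc4ncc5cc(C(=O)N(C)C)n(C6CCCC6)c5n4)cc3)CC2)cc1` differs from compound 2 by 4-methoxyphenyl in place of 3-fluorophenyl on an amide-type nitrogen. Among the compounds with values here, no measured step covers this exact change; the one step known, a number 45.9 percentage points lower from compound 1 to compound 2 (beyond the scatter), shows only that altering this ring can move the result far. The step of a number 11.8 percentage points higher from compound 2 to compound 3 (beyond the scatter) is therefore expected with little confidence, in either direction. Compound 3 is estimated at 45%, within 15% to 80%.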

Compound 3, percent growth inhibition at one concentration: 74.4%
Compound 3: middle estimate off by 29.4 percentage points, on the low side; the range from low to high includes it.
By their numbers in this assay, from the lowest: compound 2; then compounds 3 and 1 (each within the scatter of the next).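

Swapping the ring on this amide-type nitrogen gives a large rise in this assay (a number 41.2 percentage points higher from compound 2 to compound 3 (beyond the scatter)), while the change from the 2-fluorophenyl compound stays within the scatter (a number 4.7 percentage points lower from compound 1 to compound 3 (within the scatter)). A ring other than 2-fluorophenyl can therefore hold the higher level, and among these three compounds only compound 2 stands apart. No measurement here accounts for this difference.

This step changes both the group on the ring and where it sits, so the two changes cannot be separated. As far as these compounds go, how an amine or a carboxylic acid on this ring would fare remains open.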